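The source may hold more compounds than are shown below. What is called first, only, known or untested is meant among the compounds shown, and "the series" means these compounds.

In a functional assay on HL-60 cells (Homo sapiens) for antiproliferative activity, read by XTT assay, with a stated time of 72 h (on this read-out higher numbers stand for weaker inhibition and lower numbers for stronger inhibition), the three measured compounds give:

compound 1 `CN(C)c1ncnc2c1c(-c1ccsc1)cn2[C@@H]1O[C@H](CO)[C@@H](O)[C@H]1O`: 1920 nM
compound 2 `O=c1[nH]cnc2c1c(-c1cccs1)cn2[C@@H]1O[C@H](CO)[C@@H](O)[C@H]1O`: > 20000 nM, which is a limit of the assay rather than a number
compound 3 `O=c1[nH]cnc2c1c(-c1ccsc1)cn2[C@@H]1O[C@H](CO)[C@@H](O)[C@H]1O`: 12000 nM

Compound 3 therefore carries the highest of the two real numbers; the nearest is compound 1, whose value is lower by a margin beyond the usual scatter. Within the data shown here, the one measured step between neighbours, an at least 1.6-fold lower number from compound 2 to compound 3 (0.22 log units; that floor lies within the scatter), is anchored on the side of compound 2 by the limit of > 20000 nM in this assay, at which 1 of the 3 values shown sits, so it only says that compound 3 is not weaker than compound 2.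

Compound 4 `O=c1[nH]cnc2c1c(-c1cc3ccccc3o1)cn2[C@@H]1O[C@H](CO)[C@@H](O)[C@H]1O` differs from compound 3 as follows: 1-benzofuran-2-yl in place of thiophen-3-yl on an aromatic carbon. No measured pair exchanges one five-membered aromatic ring for a fused two-ring group of this kind, so none of the steps shown bears directly on this change, and the direction cannot be read from the data. The expectation for compound 4 in this assay is 10000 nM, between 2000 nM and 40000 nM. That amounts to an expected step of a 1.2-fold lower number from compound 3 to compound 4 (0.08 log units; within the scatter), essentially no change beyond the scatter.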

Compound 4, half-maximal inhibitory concentration: > 20000 nM
Compound 4 gave a limit, no number; the forecaster's own chance of this, stated with the estimate: 30%; at least 2.0-fold (0.30 log units) between middle value and limit.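

From the compounds shown here alone, putting 1-benzofuran-2-yl in place of thiophen-3-yl gives an at least 1.6-fold higher number from compound 3 to compound 4 (0.22 log units; that floor lies within the scatter), so in this assay the added six-membered aromatic ring brings no stronger inhibition at this position, though the true size of the step stays unknown. Compound 4 gives a limit, not a number: > 20000 nM. The step between compound 2 and compound 4 cannot be read, and the thiophen-2-yl and 1-benzofuran-2-yl compounds now rest at the same edge of the assay: the limit of > 20000 nM in this assay, at which 2 of the 4 values shown sit.

Going by these compounds, whether a smaller group at this position, such as a methyl, or a ring carrying an amine, would give a real number remains open. Also open, on these data alone, is how 1-benzofuran-2-yl would behave on the core of compound 1, which gives 1920 nM.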